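One ring swap and its expected effect on clearance

A few compounds are considered here, and "the series" means these few. Any claim that something is new, unique, unknown or untested is made for them only; others in the source may bear on it.

Compound 1 `C[C@@H]1CN(c2sc(C3COC3)nc2-c2nc3ccccc3[nH]2)CCN1C(=O)Cn1cnc2cccnc21`: 38 mL.min-1.g-1
Compound 2 `CCOc1ncc(-c2nc(C(F)(F)F)sc2N2CCN(C(=O)Cn3ccc4cccnc43)[C@H](C)C2)cn1`: 316 mL.min-1.g-1
Compound 3 `CCc1ncc(-c2nc(C(F)(F)F)sc2N2CCN(C(=O)Cn3nc(C)nc3C)[C@H](C)C2)cn1`: 43 mL.min-1.g-1

In a toxicity assay on microsomes from liver (Homo sapiens) for metabolic stability, read by LC-MS, using NADPH, tested at 1 uM (on this read-out lower numbers stand for slow clearance and higher numbers for fast clearance), compound 3 gives 43 mL.min-1.g-1, within the usual scatter of compound 1, while compound 2, at 316 mL.min-1.g-1, stands higher, beyond that scatter. Compound 4 `CCOc1ccc(-c2nc(C(F)(F)F)sc2N2CCN(C(=O)Cn3nc(C)nc3C)[C@H](C)C2)cn1` differs from compound 3 in one group: 6-ethoxypyridin-3-yl in place of 2-ethylpyrimidin-5-yl on an aromatic carbon. Going by the values given here, no measured pair isolates a single change, so the guidance is thin. Compound 2 also carries an ethoxy group, though it differs elsewhere too, and it gives 316 mL.min-1.g-1, so a modest rise in this assay is expected. The estimated step is a 2.3-fold higher number from compound 3 to compound 4 (0.37 log units; beyond the scatter). For compound 4 the expected value is 100 mL.min-1.g-1, with an estimated range of 45 mL.min-1.g-1 to 230 mL.min-1.g-1.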

Compound 4, intrinsic clearance in microsomes: 66 mL.min-1.g-1
Compound 4: the middle estimate sits 1.5-fold (0.18 log units) above what was measured; low and high end bracket the measured number.
By their numbers in this assay, from the lowest: compounds 1, 3 and 4 (each within the scatter of the next); then compound 2.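

In this assay, going by these compounds alone, the swap to 6-ethoxypyridin-3-yl gives a 1.5-fold higher number from compound 3 to compound 4 (0.19 log units; within the scatter) and that step lies within the usual scatter, making this the first pair to isolate a single change. On this aromatic carbon of the five-membered ring, the two groups therefore cannot be told apart by clearance. Nothing available here explains this result.

Going by these compounds, whether an amine or a carboxylic acid at this position would shift clearance remains open. So does whether this swap would behave the same way with a different group on the amide.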